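Trading 2-phenylethenyl for propyl on a shared core

This account rests on a few compounds, and the source may have more. Where it says the series, first, only, none or still open, it means among the compounds named here.

Among the measured compounds shown here, in a functional assay with Mus musculus as the target (on this read-out higher numbers stand for an effect only at larger amounts of compound and lower numbers for an effect already at smaller amounts), compound 1 (`Nc1nc(O)c2c(n1)n(C1OC(CO)[C@@H](O)[C@H]1O)c(=O)n2C/C=C/c1ccccc1`) gives 4 uM as the lower of the two numbers known so far. Compound 2 (`C=CCn1c(=S)n(C2OC(CO)[C@@H](O)[C@H]2O)c2nc(N)nc(O)c21`) gives 20 uM on the same read-out. That gap lies beyond the usual scatter, so compound 1 shows its effect at the smaller amount of the pair.

Compound 3 (`CCCCn1c(=O)n(C2OC(CO)[C@@H](O)[C@H]2O)c2nc(N)nc(O)c21`) keeps the core of compound 1 and changes one group: propyl in place of 2-phenylethenyl on a saturated chain carbon bound to an aromatic nitrogen. Cut one bond further out, the same change reads 3-phenylprop-2-en-1-yl to butyl.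

For the measured compounds named here, no measured step of this kind exists for this assay to lean on, so the expectation is a loose one. A move to a higher number is expected, probably beyond the scatter, landing in the neighbourhood of compound 2 at 20 uM on the scale. The estimated change is a 3.5-fold higher number from compound 1 to compound 3 (0.54 log units; beyond the scatter) in the direction of larger amounts. Compound 3 is expected at 14 uM with a range from 5 uM to 40 uM in this estimate.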

Compound 3, concentration for half-maximal effect: 100 uM
Estimate against measurement, compound 3: 7.1-fold (0.85 log units) below, and the stated range ends below it.
By their numbers in this assay, from the lowest: compound 1; then compound 2; then compound 3.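

In this assay, replacing 2-phenylethenyl with propyl on a saturated chain carbon bound to an aromatic nitrogen gives a large step, a 25-fold higher number from compound 1 to compound 3 (1.40 log units; beyond the scatter), which shows that the effect at this position depends strongly on the group it carries. The change removes the six-membered aromatic ring of carbon only and the double bond outside aromatic rings, and the group falls from 8 heavy atoms to 3, while hydrogen-bond donors, hydrogen-bond acceptors and net charge stay the same in both groups. No measured property is available to explain the size of this step.

The compounds shown do not separate the contributions of the ring, the double bond and the size of the group, since all of these change together in this one step. A 3-phenylpropyl group in the place of 3-phenylprop-2-en-1-yl would keep the ring without the double bond, while a chain ending in an amine or a carboxylic acid would test a different kind of group at the same position.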